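This account rests on a few compounds, and the source may have more. Where it says the series, first, only, none or still open, it means among the compounds named here.

Measured compounds in a functional assay on U-937 cells (Homo sapiens) for cytotoxicity, read by MTT assay, with a stated time of 24 h; a higher number here means a weaker inhibitor, a lower number a stronger inhibitor:
- compound 1 `CCCCCCCCCCn1cc(-c2nc3ccccc3cc2C)nn1`: > 100 ug/mL
- compound 2 `Cc1cc2ccccc2nc1-c1cn(-c2ccc(F)cc2)nn1`: 65.6 ug/mL
- compound 3 `CCc1cc2ccccc2nc1-c1cn(CCC(F)(F)C(F)(F)C(F)(F)C(F)(F)C(F)(F)C(F)(F)C(F)(F)C(F)(F)F)nn1`: 55.9 ug/mL

Compound 1 gives > 100 ug/mL, which is a limit of this assay and not a number (the limit of > 100 ug/mL in this assay, at which 1 of the 3 values shown sits). Compound 2 gives 65.6 ug/mL. Compound 3 gives 55.9 ug/mL, and the gap between compound 3 and compound 2 lies within the scatter, so the two numbers cannot be told apart. Compound 2 thus stands with compound 3 among the two numbers shown, while compound 1 sits at the limit.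

Compound 4 `CCCCc1cc2ccccc2nc1-c1cn(-c2ccc(F)cc2)nn1` is not yet measured. From compound 2 it differs by propyl in place of hydrogen on a saturated chain carbon bound to an aromatic carbon. Among the compounds with values here, no step between measured compounds covers this kind of change, so no measured size or direction is available. Compound 4 is expected to land close to compound 2, with a step of a 1.1-fold lower number from compound 2 to compound 4 (0.04 log units; within the scatter) that is taken to fall within the scatter. The estimate for compound 4 in this assay is 60 ug/mL, with a range from 25 ug/mL to 130 ug/mL.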

Compound 4, half-maximal inhibitory concentration: 66.2 ug/mL
Compound 4: the middle estimate sits 1.1-fold (0.04 log units) below what was measured, within the range that was stated.
By their numbers in this assay, from the lowest: compounds 3, 2 and 4 (each within the scatter of the next). At a limit, above all of these: compound 1.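

In this assay, the change from methyl to butyl at this place, a saturated chain carbon bound to an aromatic carbon, gives a 1.0-fold higher number from compound 2 to compound 4 (0.00 log units; within the scatter). The earlier compounds shown here differ from each other in more than one place, so they gave no reading of this position alone; here the rest of compound 2 is held fixed, and the methyl and butyl compounds cannot be told apart. No measured property among the data bears on this result.

A single step at one place leaves open whether an amine, a carboxylic acid or a chain longer than butyl on this carbon would also stay within the scatter of compound 2. Also open, from the compounds shown here alone, is whether the same change reads alike with the groups carried on the triazole nitrogen in compound 1 and compound 3.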